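A methyl on the pyrazole of compound 1

The source may report more compounds than this note shows. Statements on the series, on what has been measured and on what is new or still open speak of the compounds shown alone.

Compound 1, `C[C@@H]1CCCN1c1c(C#N)c2c(N)nc(Nc3cn[nH]c3)nc2n1C`, stands at the low end of three numbers measured in an assay on isolated protein for inhibition of Leucine-rich repeat serine/threonine-protein kinase 2 variant G2019S (Homo sapiens), read by TR-FRET and LanthaScreen, with stated times of 50 min and 30 min, in the presence of a further agent that is not named here; a higher number here means a weaker inhibitor, a lower number a stronger inhibitor: compound 1 gives 6 nM. Compound 3, `Cc1c(Nc2nc(N)c3c(C#N)c(N4CCC[C@H]4C)n(C)c3n2)cnn1CC(C)(C)O`, is the nearest to it, and in this assay compound 3 gives 35 nM. Compound 2, `Cc1cn(C)nc1Nc1cc2c(c(N)n1)c(C#N)c(N1CCC[C@H]1C)n2C`, lies furthest away, and in this assay compound 2 gives 1290 nM. The gap from compound 1 to compound 3 and the much larger gap from compound 1 to compound 2 both lie beyond the usual scatter, so compound 1 is the strongest inhibitor of the three on these numbers.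

Compound 4, `Cc1n[nH]cc1Nc1nc(N)c2c(C#N)c(N3CCC[C@H]3C)n(C)c2n1`, differs from compound 1 in one place: methyl in place of hydrogen on an aromatic carbon. Within the data shown here, no pair of measured compounds shows this exact change on its own; compound 2 and compound 3 each carry a methyl on a pyrazole carbon, but both also carry a group on the ring nitrogen, so their numbers cannot be read as the effect of the methyl alone. Since both of them sit above compound 1, a modest weakening is expected for compound 4, with the step of a 3.3-fold higher number from compound 1 to compound 4 (0.52 log units; beyond the scatter) in this assay estimated to fall somewhat beyond the scatter. Compound 4 is therefore expected to give about 20 nM in this assay, within a range from 6 nM to 70 nM.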

Compound 4, half-maximal inhibitory concentration: 27 nM
Compound 4: middle estimate off by 1.4-fold (0.13 log units), on the low side, within the range that was stated.
By their numbers in this assay, from the lowest: compound 1; then compounds 4 and 3 (each within the scatter of the next); then compound 2.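

In this assay, methyl in place of hydrogen on this aromatic carbon gives a 4.5-fold higher number from compound 1 to compound 4 (0.65 log units; beyond the scatter), a modest step that lies beyond the scatter. Among these compounds, this is the first pair in which that change stands alone, with the ring nitrogen still free of any added group, so the step can be read as belonging to the methyl itself. A methyl next to the ring atom that bears a large group therefore weakens inhibition here without abolishing it, since compound 4 still gives 27 nM, and nothing measured here accounts for a step of this size.

As far as these compounds go, whether a chlorine atom, an ethyl group or a methoxy group on this same carbon would give a step of similar size remains open, so one methyl cannot show how far this position tolerates change. It also remains open whether the methyl would give the same step if the ring nitrogen carried a group, as the compounds shown include no pair that differs in that one place.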